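Replacing dichlorobenzyl with trimethylbenzyl on a fluorophenyl triazole

A few compounds are considered here, and "the series" means these few. Any claim that something is new, unique, unknown or untested is made for them only; others in the source may bear on it.

Measured so far in a functional assay on DU-145 cells (Homo sapiens) for cytotoxicity, read by MTT assay; a lower number here means a stronger inhibitor, a higher number a weaker inhibitor:
compound 1 `COc1ccc2cc([C@H](C)c3nnc(SCc4c(C)cc(C)cc4C)n3-c3cccc(Cl)c3)ccc2c1` gives 93300 nM
compound 2 `COc1ccc2cc([C@H](C)c3nnc(SCc4c(Cl)cccc4Cl)n3-c3cccc(Cl)c3)ccc2c1` gives <= 400000 nM
compound 3 `COc1ccc2cc([C@H](C)c3nnc(SCc4c(Cl)cccc4Cl)n3-c3ccc(F)cc3)ccc2c1` gives 12300 nM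

Compound 2 shows only (the limit of <= 400000 nM in this assay, at which 1 of the 3 values shown sits), a limit of this assay and not a number. Compound 4 `COc1ccc2cc([C@H](C)c3nnc(SCc4c(C)cc(C)cc4C)n3-c3ccc(F)cc3)ccc2c1` is not yet measured. The change from compound 3 to compound 4 is 2,4,6-trimethylphenyl in place of 2,6-dichlorophenyl on a saturated chain carbon bound to a sulfur; the same change is made from compound 2 to compound 1, (2,4,6-trimethylphenyl in place of 2,6-dichlorophenyl on a saturated chain carbon bound to a sulfur), where the step is a step that the limit leaves unreadable from compound 2 to compound 1. The cores of compound 2 and compound 3 differ by 4-fluorophenyl in place of 3-chlorophenyl on an aromatic nitrogen, with the step that the limit leaves unreadable from compound 2 to compound 3. Compound 3 has the lowest number; compound 1 is higher by an amount beyond the scatter. For compound 4 the step is expected to be a 1.6-fold higher number from compound 3 to compound 4 (0.21 log units; within the scatter), resting only on compound 3 at 12300 nM, since the one earlier case of this change is unreadable. Compound 4 is expected near 20000 nM, between 5000 nM and 100000 nM.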

Compound 4, half-maximal inhibitory concentration: 10200 nM
Compound 4: middle estimate off by 2.0-fold (0.29 log units), on the high side; low and high end bracket the measured number.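

In this assay, 2,4,6-trimethylphenyl in place of 2,6-dichlorophenyl on the core of compound 3 gives a 1.2-fold lower number from compound 3 to compound 4 (0.08 log units; within the scatter), so the two groups cannot be told apart on that core. Whether the same holds on the core of compound 1 cannot be said, and neither step from compound 2 can be read, because compound 2 shows only a limit: the limit of <= 400000 nM in this assay, at which 1 of the 4 values shown sits. With the 2,4,6-trimethylphenyl group kept, 4-fluorophenyl in place of 3-chlorophenyl on an aromatic nitrogen gives a 9.1-fold lower number from compound 1 to compound 4 (0.96 log units; beyond the scatter), which shows that the core can shift the number even though this one change did not on the core of compound 3.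

The compounds shown leave open how an amine or a carboxylic acid would fare in place of the 2,4,6-trimethylphenyl group. They also leave open whether the result for this change holds on any core beyond that of compound 3.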